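The compounds below may be only part of what the source reports. "The series", "measured", "known", "first", "only" and "open" are said of these compounds alone.

Measured compounds in a functional assay on HEK293 cells for positive allosteric modulation of metabotropic glutamate receptor 5 (Rattus norvegicus), read by fluorescence and calcium flux; on this read-out lower numbers stand for smaller maximal responses and higher numbers for larger maximal responses:
compound 1 `C[C@@H](NC(=O)c1ccc(C#Cc2ccccc2)cn1)C(C)(C)O` gives 60.9%
compound 2 `Cc1ccccc1C#Cc1ccc(C(=O)N[C@H](C)C(C)(C)O)nc1` gives 59.9%
compound 3 `C[C@@H](NC(=O)c1ccc(C#CC2CCCC2)cn1)C(C)(C)O` gives 63.7%

In this assay compound 2 stands lowest of the three numbers, but its gaps to compound 1 and to compound 3 both lie within the scatter. Compound 4 `C[C@@H](NC(=O)c1ccc(C#Cc2ccc(F)cn2)cn1)C(C)(C)O` differs from compound 2 in one place: 5-fluoropyridin-2-yl in place of 2-methylphenyl on a triple-bonded carbon. Among the compounds with values here, three measured steps bear on this change, since each alters the group on the triple-bonded carbon: a number 1 percentage points lower from compound 1 to compound 2 (within the scatter), a number 2.8 percentage points higher from compound 1 to compound 3 (within the scatter) and a number 3.8 percentage points higher from compound 2 to compound 3 (within the scatter). All three stay within the scatter. Within the data shown here, no measured step introduces a ring with a hetero atom or a fluorine, so the expectation rests on these three steps alone. Compound 4 is therefore expected to give about 62%, with a range from 50% to 74%. The expected step of a number 2.1 percentage points higher from compound 2 to compound 4 (within the scatter) is thus estimated to remain within the scatter.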

Compound 4, largest response reached (reported as efficacy), in percent of the reference or control that the assay uses: 64.6%
Compound 4: the middle estimate sits 2.6 percentage points below what was measured, and the stated range covers the measured number.
By their numbers in this assay, from the lowest: compounds 2, 1, 3 and 4 (each within the scatter of the next).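

In this assay 5-fluoropyridin-2-yl on the triple-bonded carbon gives a number 4.7 percentage points higher from compound 2 to compound 4 (within the scatter) and a number 3.7 percentage points higher from compound 1 to compound 4 (within the scatter) and a number 0.9 percentage points higher from compound 3 to compound 4 (within the scatter) so a ring with a hetero atom and a fluorine cannot be told apart here from phenyl, 2-methylphenyl or cyclopentyl. Nothing given here offers an explanation for this result. The compounds shown leave open whether a longer alkyl chain, an amine or a carboxylic acid on this carbon would give a similar response, and they do not separate the contribution of the ring nitrogen from that of the fluorine.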